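A few compounds are considered here, and "the series" means these few. Any claim that something is new, unique, unknown or untested is made for them only; others in the source may bear on it.

Compound 1 `CC(C)C(=O)Nc1ccc(S(=O)(=O)Oc2ccccc2C(C)C)cc1` gives 14000 nM in a functional assay on HT-29 cells (Homo sapiens) for antiproliferative activity, read by sulforhodamine B assay, with a stated time of 48 h; a higher number here means a weaker inhibitor, a lower number a stronger inhibitor. It stands level with compound 3 `O=C(Nc1ccc(S(=O)(=O)Oc2ccccc2I)cc1)NC1CC1`, which gives 14000 nM, the two together being the highest of the three numbers, while compound 2 `CC(C)C(=O)Nc1ccc(S(=O)(=O)Oc2ccccc2I)cc1` gives 13000 nM. Both measured steps are small: a 1.1-fold lower number from compound 1 to compound 2 (0.03 log units; within the scatter) and a 1.1-fold higher number from compound 2 to compound 3 (0.03 log units; within the scatter). Compound 4 `CC(C)c1ccccc1OS(=O)(=O)c1ccc(NC(=O)NC2CCCC2)cc1` differs from compound 1 by cyclopentylamino in place of isopropyl on a carbonyl carbon. The step from compound 2 to compound 3, which also replaces isopropyl on a carbonyl carbon with a cycloalkylamino group, lay within the scatter, so no step beyond the scatter is expected in this assay from compound 1 to compound 4. Compound 4 is therefore estimated at 14000 nM, with a range from 7000 nM to 28000 nM, meaning no change at the digits printed from compound 1 to compound 4 (within the scatter).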

Compound 4, half-maximal inhibitory concentration: 7400 nM
The estimate for compound 4 lay 1.9-fold (0.28 log units) above the measured number; measured number inside the range.
By their numbers in this assay, from the lowest: compounds 4, 2, 1 and 3 (each within the scatter of the next).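

With isopropyl kept on the aromatic carbon, cyclopentylamino on the carbonyl carbon gives a 1.9-fold lower number from compound 1 to compound 4 (0.28 log units; within the scatter), so the scatter still covers this change. The earlier replacement at this carbonyl carbon was cyclopropylamino, and only with iodo on the aromatic carbon; the five-membered ring now extends the finding to a second cycloalkylamino group and to the isopropyl compound. No available evidence bears on this result.

From the compounds shown here alone, it remains open whether cyclohexylamino, an open-chain butylamino group or a piperidine would move the number beyond the scatter in this assay. Also open, going by these compounds, is how cyclopentylamino behaves alongside iodo.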